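A few compounds are considered here, and "the series" means these few. Any claim that something is new, unique, unknown or untested is made for them only; others in the source may bear on it.

Working notes on a series of ureas sharing one core, read in a functional assay on the whole organism with Mus musculus as the target, in the maximal electroshock model, with a stated time of 30 min; on this read-out lower numbers stand for an effect already at smaller amounts and higher numbers for an effect only at larger amounts of compound. Compound 1 `Cc1cccc(Cl)c1NC(=O)Nc1ccncc1` gives 30 mg/kg and holds the lowest of the two numbers seen in this assay. Compound 2 `Cc1cc(C)c(NC(=O)Nc2ccncc2)c(Cl)c1`, carrying methyl in place of hydrogen on an aromatic carbon, gives 100 mg/kg; the step is a 3.3-fold higher number from compound 1 to compound 2 (0.52 log units; beyond the scatter). Compound 3 `O=C(Nc1ccncc1)Nc1c(Cl)cccc1CO`, with hydroxy in place of hydrogen on a saturated chain carbon bound to an aromatic carbon, reaches only a limit of this assay, > 300 mg/kg. The step to it is an at least 10-fold higher number from compound 1 to compound 3 (1.00 log units; beyond the scatter); one of the three values sits at the limit of > 300 mg/kg in this assay, at which 1 of the 3 values shown sits. Each change made so far from compound 1 has moved the number up.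

Compound 4 `Cc1cccc(Cl)c1NC(=O)Nc1ccccn1` has the same atoms as compound 1, joined differently: pyridin-2-yl in place of pyridin-4-yl on an amide-type nitrogen. Neither measured step touches the pyridinyl side of the urea, so none bears directly on this change. Both measured steps were modest or larger and pointed toward higher numbers, and the ring change here is no smaller a change, so a modest rise rather than no change is expected, with wide uncertainty. For compound 4 the estimate in this assay is 100 mg/kg, between 30 mg/kg and 300 mg/kg. That estimate means a step of a 3.3-fold higher number from compound 1 to compound 4 (0.52 log units; beyond the scatter), expected to lie beyond the scatter but uncertain in size.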

Compound 4, minimum effective dose: 100 mg/kg
Beside the measured number, compound 4's estimate shows no gap at the digits printed; the measured number falls inside the stated range.
By their numbers in this assay, from the lowest: compound 1; then compounds 2 and 4 (each within the scatter of the next). At a limit, above all of these: compound 3.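

Among these compounds, the pyridinyl side of the urea, untouched by the earlier steps, also matters in this assay: pyridin-2-yl in place of pyridin-4-yl on the amide-type nitrogen gives a 3.3-fold higher number from compound 1 to compound 4 (0.52 log units; beyond the scatter) even though the two groups match in heavy atoms and in counted hydrogen-bond donors and acceptors. A different attachment of the same ring, with no atom added or lost, is therefore enough to move the number beyond the scatter, and compound 1 still holds the lowest number of the series, now with a measured change on this side of the urea as well. Nothing in the data shown accounts for this step.

From the compounds shown here alone, it remains open whether pyridin-3-yl on the same amide-type nitrogen would read like compound 1, like compound 4 or differently from both, and whether a plain phenyl ring there would keep any effect in this assay. Also open, going by these compounds, is whether a methoxy group or an amine on the pyridinyl ring of compound 1 could bring the number lower than the value of compound 1.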